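Methyl in place of phenyl on the shared core

The source may hold more compounds than are shown below. What is called first, only, known or untested is meant among the compounds shown, and "the series" means these compounds.

Compound 3 `Cn1c(=O)c2nc(-c3ccc(-c4ccccc4)cc3)[nH]c2n(C)c1=O` carries a phenyl group on the aromatic carbon of the shared core. In an assay for binding affinity to adenosine receptor A1 (Bos taurus) (on this read-out higher numbers stand for weaker inhibition and lower numbers for stronger inhibition), compound 3 gives 3.5 nM, the highest number of the three measured compounds. Compound 1 `CSc1ccc(-c2nc3c(=O)n(C)c(=O)n(C)c3[nH]2)cc1` gives 2 nM in this assay, and compound 2 `Cn1c(=O)c2nc(-c3ccc(I)cc3)[nH]c2n(C)c1=O` gives 1.3 nM. The step of a 1.8-fold higher number from compound 1 to compound 3 (0.24 log units; within the scatter) lies within the scatter, whereas the step of a 2.7-fold higher number from compound 2 to compound 3 (0.43 log units; beyond the scatter) is a modest change, and a 1.5-fold lower number from compound 1 to compound 2 (0.19 log units; within the scatter) is within the scatter as well.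

Compound 4 `Cc1ccc(-c2nc3c(=O)n(C)c(=O)n(C)c3[nH]2)cc1` differs from compound 3 by methyl in place of phenyl on an aromatic carbon. Among the measured compounds shown here, no measured step exchanges phenyl for methyl, so the expectation rests on the fact that methylsulfanyl, iodo and phenyl at this place all give numbers within a narrow band. A methyl group, smaller than the phenyl it replaces, is therefore expected to leave this assay almost unchanged, with the estimated step of a 1.4-fold lower number from compound 3 to compound 4 (0.15 log units; within the scatter) staying within the scatter. The expected value for compound 4 is 2.5 nM, with a range from 1 nM to 6 nM.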

Compound 4, half-maximal inhibitory concentration: 0.8 nM
For compound 4 the middle estimate is 3.1-fold (0.49 log units) above the measured one; measured number below the stated range.
By their numbers in this assay, from the lowest: compounds 4, 2, 1 and 3 (each within the scatter of the next, the first and the last beyond it).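

In this assay, methyl in place of phenyl lowers the number by the largest step yet seen on this aromatic carbon (a 4.4-fold lower number from compound 3 to compound 4 (0.64 log units; beyond the scatter)), so a group with no ring serves here at least as well as the phenyl ring. Methyl also stands clearly apart from methylsulfanyl (a 2.5-fold lower number from compound 1 to compound 4 (0.40 log units; beyond the scatter)) but cannot be told apart from iodo (a 1.6-fold lower number from compound 2 to compound 4 (0.21 log units; within the scatter)), which places methyl and iodo together at the low end of the numbers. Nothing available explains why these groups differ.

On these data alone, whether an ethyl group or a longer chain would keep the low number seen with methyl remains open, as does the outcome with an amine or a carboxylic acid at this place. With only four groups compared at one position, these steps describe these compounds and support no wider rule.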